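Formamide to acetamide to benzyl carbamate in a dog assay

The compounds below may be only part of what the source reports. "The series", "measured", "known", "first", "only" and "open" are said of these compounds alone.

Measured compounds:
compound 1, `Cc1nc2c(OCc3ccccc3)cccn2c1NC=O`, 3%
compound 2, `CC(=O)Nc1c(C)nc2c(OCc3ccccc3)cccn12`, 24%

Among the compounds with values here, only two numbers are in hand. In a functional assay on the whole organism with Canis familiaris (Canis lupus familiaris) as the target, at a dose of 2 mg/kg by the intravenous route (a lower number here means a weaker effect, a higher number a stronger effect of the compound at the dose given), compound 2 gives 24%, the higher of the two, while compound 1 gives 3%. Within the data shown here, the single step in the set, a number 21 percentage points higher from compound 1 to compound 2 (beyond the scatter), is the only guide available.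

Compound 3, `Cc1nc2c(OCc3ccccc3)cccn2c1NC(=O)OCc1ccccc1`, has not yet been measured in this assay. Its difference from compound 2 is benzyloxy in place of methyl on a carbonyl carbon. Among the measured compounds shown here, the step from compound 1 to compound 2 also altered the substituent on that same carbonyl carbon, and growth there, from hydrogen to methyl, went with a rise beyond the scatter; no step in hand tests benzyloxy itself, nor any group of comparable size at that place. Taking the one measured step as the nearest indication, a further rise of modest size is expected, though an outcome within the scatter of compound 2 cannot be excluded. The expected step is a number 11 percentage points higher from compound 2 to compound 3 (beyond the scatter). Compound 3 is thus estimated to give 35%, within a range of 10% to 65%.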

Compound 3, a percentage reported as inhibition, in the whole organism at one dose (the size of the read-out at that dose, not a potency): 82%
Compound 3: the middle estimate sits 47 percentage points below what was measured; the measured number lies above the stated range.
By their numbers in this assay, from the lowest: compound 1; then compound 2; then compound 3.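

In this assay, the group on the carbonyl carbon whose other neighbour is the amide-type nitrogen turns out to carry far more weight than the earlier pair showed: against the modest a number 21 percentage points higher from compound 1 to compound 2 (beyond the scatter), benzyloxy in place of methyl gives a number 58 percentage points higher from compound 2 to compound 3 (beyond the scatter), a large step. Across the three compounds, the read-out rises from hydrogen through methyl to benzyloxy with no compound against that order, and the full change from hydrogen to benzyloxy amounts to a number 79 percentage points higher from compound 1 to compound 3 (beyond the scatter), so this single place spans most of the range seen in the series. Nothing at hand bears on the reason for this rise.

Open, going by these compounds, is whether a methoxy or a plain benzyl group on that carbonyl carbon would keep the high read-out, which would separate the contribution of the entering oxygen from that of the aromatic ring. Also open, on these data alone, is whether a longer chain or a substituted benzyloxy would go further, and how these compounds would compare at other doses in this assay, since a single dose gives no potency.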